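The source may report more compounds than this note shows. Statements on the series, on what has been measured and on what is new or still open speak of the compounds shown alone.

Compound 1 `CSc1nncc2c(C)nc(C(C)C)n12`: in a functional assay for inhibition, with Homo sapiens as the target (a lower number here means a stronger inhibitor, a higher number a weaker inhibitor), compound 1 gives > 48000 nM, a limit of the assay.
Compound 2 `Cc1ncn2c(S)nncc12`: in this assay compound 2 gives > 48000 nM, also a limit.

Compound 2 thus stands at the limit of > 48000 nM in this assay, at which 2 of the 2 values shown sit, and no number separates it from compound 1. Compound 3 `Cc1nc(C(C)C)n2c(S)nncc12` differs from compound 2 by isopropyl in place of hydrogen on an aromatic carbon. Going by the values given here, no measured step of this kind exists here, and compound 1, which carries the same isopropyl, also sits at the limit. The expected step that the limit leaves unreadable from compound 2 to compound 3 is therefore none beyond the scatter. Compound 3 is estimated at 60000 nM, between 20000 nM and 200000 nM, most likely again a limit.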

Compound 3, half-maximal inhibitory concentration: > 48000 nM
Compound 3 ended at the assay's limit; the forecaster's own chance of this, stated with the estimate: 80%; the middle value lies beyond the limit too.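

No step can be read from compound 1 or compound 2 to compound 3, because all three compounds stand at the same limit: the limit of > 48000 nM in this assay, at which 3 of the 3 values shown sit.

The compounds shown leave open how strong an inhibitor each one really is, and whether isopropyl in place of hydrogen changes that.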